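The source may hold more compounds than are shown below. What is called first, only, known or untested is meant among the compounds shown, and "the series" means these compounds.

In an ADME assay on the whole organism (Mus musculus, strain BALB/c) for pharmacokinetics, read by LC-MS, at a dose of 10 mg/kg by the oral route (a lower number here means less compound in the circulation, a higher number more compound in the circulation at the dose given), compound 1 `COC(=O)NC12CCC(n3cc(-c4ccc(Cl)c(N)c4)c4c(N)ncnc43)(CC1)CC2` gives 9500 nM and compound 2 `COC(=O)N[C@H]1CC[C@@H](n2cc(-c3ccc(Cl)c(N)c3)c3c(N)ncnc32)CC1` gives 10000 nM, two values within the usual scatter of each other. Compound 3 `COC(=O)NC12CCC(n3cc(-c4cc(N)c(Cl)cc4F)c4c(N)ncnc43)(CC1)CC2` differs from compound 1 by one change: fluoro in place of hydrogen on an aromatic carbon. This places fluoro in place of hydrogen on an aromatic carbon, turning 3-amino-4-chlorophenyl into 5-amino-4-chloro-2-fluorophenyl. Among the measured compounds shown here, no measured pair shows this change, so the size of its effect in this assay is not known from the series. The expected step, a 1.1-fold lower number from compound 1 to compound 3 (0.05 log units; within the scatter), stays within the scatter, with neither direction favoured. For compound 3 the estimated value is 8500 nM, with an expected range of 3500 nM to 17000 nM.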

Compound 3, maximal plasma concentration: 7900 nM
For compound 3 the middle estimate is 1.1-fold (0.03 log units) above the measured one; measured number inside the range.
By their numbers in this assay, from the lowest: compounds 3, 1 and 2 (each within the scatter of the next).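

Among the compounds shown here, this position on the aryl ring, ortho to a large group and para to the amino group, now has a first reading in this assay: fluoro in place of hydrogen gives a 1.2-fold lower number from compound 1 to compound 3 (0.08 log units; within the scatter). At this position, the change to 5-amino-4-chloro-2-fluorophenyl therefore leaves the read-out within the scatter. Nothing shown bears on the reason for this result.

Going by these compounds, whether a larger replacement here, such as methoxy or a nitrile, would give a step beyond the scatter remains open. So does whether fluoro gives a similar step on compound 2.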